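Truncating the side-chain benzyl ester on the amide core

This account rests on a few compounds, and the source may have more. Where it says the series, first, only, none or still open, it means among the compounds named here.

Measured so far:
compound 1 `O=C(CC[C@H](NC(=O)c1cc2ccccc2cn1)C(=O)OCc1ccccc1)OCc1ccccc1`, 83.6 nM
compound 2 `O=C(C[C@H](NC(=O)c1cc2ccccc2cn1)C(=O)OCc1ccccc1)OCc1ccccc1`, 74 nM

Both numbers come from a functional assay on HL-60 cells (Homo sapiens) for antiproliferative activity, read by MTT assay, with a stated time of 48 h; on this read-out higher numbers stand for weaker inhibition and lower numbers for stronger inhibition. Compound 2 holds the lowest of the two numbers, but the step of a 1.1-fold lower number from compound 1 to compound 2 (0.05 log units; within the scatter) lies within the scatter, so no order between compound 1 and compound 2 is claimed. Shortening the side chain by one carbon thus left the read-out unchanged.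

Compound 3 `C[C@H](NC(=O)c1cc2ccccc2cn1)C(=O)OCc1ccccc1` differs from compound 2 by hydrogen in place of benzyloxycarbonyl on a saturated chain carbon, two bonds along the chain from an amide-type nitrogen and a carbonyl carbon. Among the measured compounds shown here, the only measured step bears on it only loosely: that step shortened the side chain, whereas here the whole side-chain ester is removed. For the measured compounds named here, no measured pair tests loss of the group itself, so the expectation is wide. A step of a 2.7-fold higher number from compound 2 to compound 3 (0.43 log units; beyond the scatter) toward a higher number is expected, because the shortening in a 1.1-fold lower number from compound 1 to compound 2 (0.05 log units; within the scatter) gave no gain and a full removal is a larger change. Compound 3 is expected at 200 nM, within 60 nM to 800 nM.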

Compound 3, half-maximal inhibitory concentration: 84.8 nM
Compound 3: middle estimate off by 2.4-fold (0.37 log units), on the high side, and the stated range covers the measured number.
By their numbers in this assay, from the lowest: compounds 2, 1 and 3 (each within the scatter of the next).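

In this assay, the full loss of the side-chain ester gives a 1.1-fold higher number from compound 2 to compound 3 (0.06 log units; within the scatter) and a 1.0-fold higher number from compound 1 to compound 3 (0.01 log units; within the scatter), so compounds 1, 2 and 3 cannot be told apart. The earlier pair tested only benzyloxycarbonyl against (benzyloxycarbonyl)methyl; this result shows that, on a saturated chain carbon two bonds along the chain from an amide-type nitrogen and a carbonyl carbon, the series also tolerates hydrogen in place of benzyloxycarbonyl, a loss of 10 heavy atoms including one six-membered aromatic ring of carbon only. No supporting data are available to explain this result.

Still open, as far as these compounds go, is whether a carboxylic acid or an amine in place of the methyl of compound 3 would separate from these three numbers. Also open, from the compounds shown here alone, is whether the benzyloxycarbonyl shared by compounds 1, 2 and 3 is needed, for instance against a carboxylic acid at that place.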